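This account rests on a few compounds, and the source may have more. Where it says the series, first, only, none or still open, it means among the compounds named here.

The measured compounds:
Compound 1, `Cc1cc(-c2cnn3c(NCC4CCOCC4)nc(NC4CCOCC4)nc23)ccc1C(=O)NC1CC1`: 540 nM
Compound 2, `O=C(NC1CC1)c1ccc(-c2cnn3c(NCC4CCOCC4)nc(NC4CCCC4)nc23)cc1F`: 1400 nM

Both numbers come from a functional assay on MDA-MB-231 cells (Homo sapiens) for antiproliferative activity; a higher number here means a weaker inhibitor of growth, a lower number a stronger inhibitor of growth. Of the two, compound 1 gives the lower number, 540 nM, while compound 2 gives 1400 nM, a gap beyond the usual scatter; since these two compounds differ in more than one place, the data do not tie that gap to any single change. Compound 3, `Cc1cc(-c2cnn3c(NCC4CCOCC4)nc(Nc4cccc(F)c4)nc23)ccc1C(=O)NC1CC1`, is not yet measured. It differs from compound 1 in one place: 3-fluorophenyl in place of oxan-4-yl on a nitrogen on an aromatic ring. Among the measured compounds shown here, no measured pair shows this change on its own, so nothing in the data sets its size or direction. In this assay the expected step is a 1.3-fold higher number from compound 1 to compound 3 (0.11 log units; within the scatter), which is none beyond the scatter. Compound 3 is accordingly estimated at 700 nM in this assay, with a range from 200 nM to 2500 nM.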

Compound 3, concentration for 50% growth inhibition: 16 nM
Compound 3: the middle estimate sits 44-fold (1.64 log units) above what was measured, outside the stated range (below it).
By their numbers in this assay, from the lowest: compound 3; then compound 1; then compound 2.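

In this assay, the swap of oxan-4-yl for 3-fluorophenyl on a nitrogen on an aromatic ring gives a 34-fold lower number from compound 1 to compound 3 (1.53 log units; beyond the scatter). Among the compounds shown here, this is the first change in the set that can be read on its own, and it shows that the group on this nitrogen has a large bearing on growth inhibition, which the gap between compound 1 and compound 2 could not show. Nothing measured here explains the size of the step.

The single step changes a non-aromatic ring with one hetero atom into an aromatic ring of carbon only that carries fluorine, so the compounds shown do not separate the part played by the ring from that played by the fluorine. Going by these compounds, whether plain phenyl, a pyridine ring or a chlorophenyl group would keep this gain remains open.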